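The source may hold more compounds than are shown below. What is called first, only, known or untested is meant among the compounds shown, and "the series" means these compounds.

In a functional assay on U-937 cells (Homo sapiens) for antiproliferative activity, read by MTT assay (a higher number here means a weaker inhibitor, a lower number a stronger inhibitor), three compounds have been measured so far. Compound 1 `COc1ccc(-c2cc(CN(c3nc4ccc(F)cc4s3)c3nc4ccc(OC)cc4s3)on2)cc1` gives 138000 nM. Compound 2 `COc1ccc2nc(N(Cc3cc(-c4ccc(Br)cc4)no3)c3nc4ccc(F)cc4s3)sc2c1` differs from compound 1 in one place, (bromo in place of methoxy on an aromatic carbon), and compound 2 gives 34900 nM. That single change brought a 4.0-fold lower number from compound 1 to compound 2 (0.60 log units; beyond the scatter). Compound 3 `COc1ccc(-c2cc(CN(c3ncccn3)c3nc4ccccc4s3)on2)cc1` is built on a different core, and the difference between its core and the core of compound 1 is not broken down here. In this assay compound 3 gives 13900 nM, the lowest of the three numbers.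

Compound 4 `Brc1ccc(-c2cc(CN(c3ncccn3)c3nc4ccccc4s3)on2)cc1` has not yet been measured. It differs from compound 3 by bromo in place of methoxy on an aromatic carbon, the same change, at the same place, that separates compound 1 from compound 2. Among the compounds shown this change has been made once before, so the only guide to what it may do is the step from compound 1 to compound 2. Carrying that step over to the new core, the expected change is a 3.5-fold lower number from compound 3 to compound 4 (0.54 log units; beyond the scatter), and this expectation rests on a 4.0-fold lower number from compound 1 to compound 2 (0.60 log units; beyond the scatter). Because the new core of compound 3 gives 13900 nM as its starting point, compound 4 is expected to come in near 4000 nM, with a plausible range estimated from 1500 nM to 12000 nM. Whether a single earlier example transfers across cores remains to be seen in the measurement itself.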

Compound 4, half-maximal inhibitory concentration: 13600 nM
For compound 4 the middle estimate is 3.4-fold (0.53 log units) below the measured one; measured number above the stated range.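

In this assay, replacing the 4-methoxyphenyl group with a 4-bromophenyl group on the core of compound 3 gave a 1.0-fold lower number from compound 3 to compound 4 (0.01 log units; within the scatter), so on this core the exchange produced no difference that can be separated from the ordinary scatter of repeated measurements. The same exchange therefore did not carry over at the same size from one core to the other, and the two results clearly disagree: the same change on two cores in this assay, a 4.0-fold lower number (0.60 log units; beyond the scatter) from compound 1 to compound 2 and a 1.0-fold lower number (0.01 log units; within the scatter) from compound 3 to compound 4, 3.9-fold (0.59 log units) apart, beyond the scatter of two such steps. Among the compounds shown here, with only two pairs, this shows that the step seen on the core of compound 1 cannot be treated as a general rule for this series, but it does not show why the two cores respond differently, or which result a third core would resemble.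

The compounds shown leave open what other groups on the same aromatic carbon would do on either core, for example an amine or a carboxylic acid in place of the bromo group. Also open is which feature of the core matters: no pair shown alters the core in a single place while the group on the aromatic ring stays fixed.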